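The compounds below may be only part of what the source reports. "The series", "measured", "known", "first", "only" and "open" are said of these compounds alone.

Compound 1 `CCOc1ccc(-c2c(C(=O)c3cc(OC)c(OC)c(OC)c3)sc3ccccc23)cc1`: 3100 nM
Compound 2 `COc1cc(C(=O)c2sc3ccccc3c2Nc2ccc(C)cc2)cc(OC)c1OC`: 2600 nM

In a functional assay on A549 cells (Homo sapiens) for antiproliferative activity, read by MTT assay, with a stated time of 72 h (a higher number here means a weaker inhibitor, a lower number a stronger inhibitor), compound 2 gives 2600 nM and compound 1 gives 3100 nM, so the two lie within the scatter of each other and neither stands apart. Compound 3 `CCOc1ccc(Nc2c(C(=O)c3cc(OC)c(OC)c(OC)c3)sc3ccccc23)cc1` keeps the core of compound 2 and carries ethoxy in place of methyl on an aromatic carbon. The new group sits para to a large group, and the same difference reads as (4-methylphenyl)amino to (4-ethoxyphenyl)amino.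

Within the data shown here, only one measured step bears on this change: a 1.2-fold lower number from compound 1 to compound 2 (0.08 log units; within the scatter). That step puts (4-methylphenyl)amino in place of 4-ethoxyphenyl, so it alters the ethoxy and the amino link together, and the data do not separate the two. Since it stayed within the scatter, nothing measured points to a large shift in either direction in this assay. The expected change is a 1.3-fold lower number from compound 2 to compound 3 (0.11 log units; within the scatter), which is no step beyond the scatter. For compound 3 the estimated value is 2000 nM, with an expected range from 600 nM to 5500 nM.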

Compound 3, half-maximal inhibitory concentration: 1400 nM
Beside the measured number, compound 3's estimate is 1.4-fold (0.15 log units) above it; the measured number falls inside the stated range.
By their numbers in this assay, from the lowest: compounds 3, 2 and 1 (each within the scatter of the next, the first and the last beyond it).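

In this assay the new compound pulls apart the two changes that the step from the earlier pair had made together. Among these compounds, with the 4-ethoxyphenyl group kept in both compounds, adding the amino link gives a 2.2-fold lower number from compound 1 to compound 3 (0.35 log units; beyond the scatter) and so stands as a modest change that can be read on its own, which the earlier compounds did not allow. Ethoxy in place of methyl on an aromatic carbon, para to a large group, gives a 1.9-fold lower number from compound 2 to compound 3 (0.27 log units; within the scatter) and so adds no step beyond the scatter at this position, though the (4-ethoxyphenyl)amino compound sits with the amino compound carrying methyl and apart from the compound lacking the link.

The compounds shown leave open whether a longer chain such as butoxy, or an amine or a carboxylic acid, at this same position would move the number beyond the scatter, and whether the amino link would give a similar step with a group other than ethoxy. Nothing shown here gives a reason for either step.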